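Working notes: from compound 2 to compound 4

The source may hold more compounds than are shown below. What is called first, only, known or untested is meant among the compounds shown, and "the series" means these compounds.

- compound 1 `CCOC(=O)/C=C/c1ccc(NC(=O)C2(NC(=O)c3ccc4c(C5CCCC5)c(-c5ncc(Cl)cn5)n(C)c4c3)CCC2)cc1OCC`: > 5 h
- compound 2 `CCCOC(=O)/C=C/c1ccc(NC(=O)C2(NC(=O)c3ccc4c(C5CCCC5)c(-c5ncc(Cl)cn5)n(C)c4c3)CCC2)cc1OCC`: > 5 h
- compound 3 `CCOc1cc(NC(=O)C2(NC(=O)c3ccc4c(C5CCCC5)c(-c5ncc(Cl)cn5)n(C)c4c3)CCC2)ccc1/C=C/C(=O)OCc1ccccc1`: > 5 h
- compound 4 `CCOc1cc(NC(=O)C2(NC(=O)c3ccc4c(C5CCCC5)c(-c5ncc(Cl)cn5)n(C)c4c3)CCC2)ccc1/C=C/C(=O)OCC(=O)N1CCOCC1`: not yet measured

In an ADME assay (intestine, Rattus norvegicus) for pharmacokinetics, using microsomes (a lower number here means that the compound disappears faster, a higher number that the compound lasts longer), compound 2 gives > 5 h, which is a limit and not a number. Among the compounds with values here, the whole series so far rests on (the limit of > 5 h in this assay, at which 3 of the 3 values shown sit).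

Compound 4 differs from compound 2 by (morpholin-4-yl)carbonyl in place of ethyl on a saturated chain carbon bound to an oxygen next to a carbonyl group.

Within the data shown here, three measured steps bear on this change: a step that the two limits leave unreadable from compound 2 to compound 3, a step that the two limits leave unreadable from compound 1 to compound 3 and a step that the two limits leave unreadable from compound 1 to compound 2. None of them has a readable size, and none brings in (morpholin-4-yl)carbonyl, so they give no direction.

In this assay the expected change is a step that the limit leaves unreadable from compound 2 to compound 4, with no step beyond the scatter expected in either direction. For compound 4 the estimate is 6 h, with an expected range from 2 h to 12 h.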

Compound 4, half-life: 1.27 h
For compound 4 the middle estimate is 4.7-fold (0.67 log units) above the measured one; the measured number lies below the stated range.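

In this assay, within the data shown here, (morpholin-4-yl)carbonyl on the saturated chain carbon bound to an oxygen next to a carbonyl group gives the first readable steps at this position: an at least 3.9-fold lower number from compound 2 to compound 4 (0.59 log units; beyond the scatter), an at least 3.9-fold lower number from compound 3 to compound 4 (0.59 log units; beyond the scatter) and an at least 3.9-fold lower number from compound 1 to compound 4 (0.59 log units; beyond the scatter). The steps among compound 1, compound 2 and compound 3 cannot be read, so methyl, ethyl and phenyl at this place stay unresolved: the limit of > 5 h in this assay, at which 3 of the 4 values shown sit. Compound 4 is thus the only compound shown with a number rather than a limit.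

On these data alone, whether the shorter half-life needs the six-membered non-aromatic ring remains open, and a dimethylamino carbonyl group in the same place would test this. As far as these compounds go, how far compound 1, compound 2 and compound 3 differ beyond their limits also remains open.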